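Methoxy in place of methyl: what to expect for compound 4

This account rests on a few compounds, and the source may have more. Where it says the series, first, only, none or still open, it means among the compounds named here.

The three measured compounds share the core of compound 1 `O=C(Nc1cccc(C(=O)O)c1)N[C@H]1CC[C@H](Oc2ccc(F)cc2)CC1`. In a functional assay on CRL2813 cells (Homo sapiens) for cytotoxicity, read by sulforhodamine B assay, with a stated time of 5 days (a lower number here means a stronger inhibitor, a higher number a weaker inhibitor), compound 1 reaches only the limit of the assay, > 20000 nM. Compound 2 `COC(=O)c1ccc(NC(=O)N[C@H]2CC[C@H](Oc3ccc(F)cc3)CC2)cc1`, which carries a methoxycarbonyl group, gives 11600 nM in this assay. Compound 3 `Cc1ccc(NC(=O)N[C@H]2CC[C@H](Oc3ccc(F)cc3)CC2)cc1` in this assay also returns a limit rather than a number, > 20000 nM. Compound 3 therefore stands at the limit of > 20000 nM in this assay, at which 2 of the 3 values shown sit.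

Compound 4 `COc1ccc(NC(=O)N[C@H]2CC[C@H](Oc3ccc(F)cc3)CC2)cc1` differs from compound 3 by methoxy in place of methyl on an aromatic carbon. Among the compounds with values here, the one readable step at this position is an at least 1.7-fold higher number from compound 2 to compound 3 (0.23 log units; that floor lies within the scatter), a small move whose floor lies within the scatter; the step that the two limits leave unreadable from compound 1 to compound 3 gives no size. Within the data shown here, neither step involves a methoxy group, so the expectation rests on the weak pull of compound 2 11600 nM, the one measured compound that returns a readable number. A step of an at least 1.1-fold lower number from compound 3 to compound 4 (0.04 log units; that floor lies within the scatter) is expected, with no change beyond the scatter the most likely outcome. Compound 4 is estimated at 18000 nM, in the range 7000 nM to 40000 nM, with a fair chance that only a limit is reported again.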

Compound 4, half-maximal inhibitory concentration: > 20000 nM
Compound 4: a limit, no number; the forecaster's own chance of this, stated with the estimate: 50%; middle value at least 1.1-fold (0.04 log units) from the limit.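

In this assay compound 4 returns only a limit (> 20000 nM) and so, at this place para to a large group, methoxy in place of methyl gives no readable number. Set against compound 2, the one compound with a number, the change gives an at least 1.7-fold higher number from compound 2 to compound 4 (0.23 log units; that floor lies within the scatter) and thus no separation beyond the scatter, while the other new steps, with limits at both ends, cannot be read. Of the groups shown, methoxycarbonyl alone gives a number, and the limit now holds most of the set: (the limit of > 20000 nM in this assay, at which 3 of the 4 values shown sit).

From the compounds shown here alone, the size of the step from methyl to methoxy stays open, and so does any real difference between compound 2 and the compounds at the limit. Going by these compounds, whether an amine, a hydroxyl or an ethoxycarbonyl group at this place would return a number also remains unknown.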